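Working notes: compound 4, a difluoropyridyl analogue of compound 3

The source may report more compounds than this note shows. Statements on the series, on what has been measured and on what is new or still open speak of the compounds shown alone.

Measured compounds:
- compound 1 `O=C(O)Cc1sc(C(c2ccccc2)c2ccccc2)nc1-c1ccccc1` gives 570 nM in an in vitro assay on HEK385-7 cells for displacement of a labelled ligand from prostaglandin D2 receptor 2 (Homo sapiens); on this read-out lower numbers stand for stronger inhibition and higher numbers for weaker inhibition
- compound 2 `O=C(O)Cc1sc(C(c2ccc(F)cc2)c2ccc(F)cc2)nc1-c1ccnc(F)c1` gives 0.48 nM in this assay
- compound 3 `O=C(O)Cc1sc(C(c2ccc(F)cc2)c2ccc(F)cc2)nc1-c1ccnc(N2CCCC2)c1` gives 230 nM in this assay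

Compound 3 stands second highest of the three numbers in this assay; compound 1 is nearest, above it, and compound 2 furthest, far below it. Compound 4 `O=C(O)Cc1sc(C(c2ccc(F)cc2)c2ccc(F)cc2)nc1-c1cc(F)nc(F)c1` differs from compound 3 in one place: 2,6-difluoropyridin-4-yl in place of 2-(pyrrolidin-1-yl)pyridin-4-yl on an aromatic carbon. Among the measured compounds shown here, one measured step bears on this change: a 480-fold higher number from compound 2 to compound 3 (2.68 log units; beyond the scatter). Compound 4 reverses that exchange and carries a second fluoro on the same ring, so a large downward step in this assay is expected, a 330-fold lower number from compound 3 to compound 4 (2.52 log units; beyond the scatter). Compound 4 is estimated at 0.7 nM, with a range from 0.2 nM to 3 nM.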

Compound 4, half-maximal inhibitory concentration: 5.4 nM
The estimate for compound 4 lay 7.7-fold (0.89 log units) below the measured number; measured number above the stated range.
By their numbers in this assay, from the lowest: compound 2; then compound 4; then compound 3; then compound 1.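

In this assay, 2,6-difluoropyridin-4-yl in place of 2-(pyrrolidin-1-yl)pyridin-4-yl gives a 43-fold lower number from compound 3 to compound 4 (1.63 log units; beyond the scatter) and recovers most, but not all, of the gap between compound 2 and compound 3. The second fluoro is not silent at this position: fluoro in place of hydrogen on an aromatic carbon gives an 11-fold higher number from compound 2 to compound 4 (1.05 log units; beyond the scatter) on the same core. From the compounds shown here alone, whether this loss is specific to fluoro stays open, and a chloro, methoxy or dimethylamino group in that place would test it. No measurement here accounts for either step.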